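The source may hold more compounds than are shown below. What is called first, only, known or untested is meant among the compounds shown, and "the series" means these compounds.

In a functional assay on MCF7 cells (Homo sapiens) for inhibition (a lower number here means a stronger inhibitor, a higher number a weaker inhibitor), three compounds that share one core have been measured. Compound 1 `C=C/C(C)=C/[C@@]1(C)SC(=O)C=C1O` gives 40.3 ug/mL, compound 2 `CCCCCC[C@@]1(C)SC(O)=CC1=O` gives 16.5 ug/mL, and compound 3 `CCCCCCCC[C@@]1(C)SC(O)=CC1=O` gives 12.6 ug/mL. On these numbers, compound 3 cannot be told apart from compound 2, while compound 1 stands clearly higher than both.

The next compound, compound 4 `CCCCCCCC[C@@]1(C)SC(O)=C(C)C1=O`, departs from compound 3 in a single place: methyl in place of hydrogen on a double-bonded ring carbon. In short, it has methyl in place of hydrogen on a double-bonded ring carbon. For the measured compounds named here, none of the measured compounds carries a methyl there, so the data hold no direct precedent for this change.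

Going by the values given here, the only measured step between compounds that differ in one place is a 1.3-fold lower number from compound 2 to compound 3 (0.12 log units; within the scatter). It lies on a saturated chain carbon and not on a double-bonded ring carbon, so it bears on the new change only indirectly. Resting on that small step, no shift beyond the scatter is expected in this assay, and neither direction is favoured. The range must stay wide, since nothing has yet been measured at this place. The expected change is a 1.1-fold higher number from compound 3 to compound 4 (0.05 log units; within the scatter). Compound 4 is estimated at 14 ug/mL, with an expected range from 6.5 ug/mL to 32 ug/mL.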

Compound 4, half-maximal inhibitory concentration: 16.5 ug/mL
The estimate for compound 4 lay 1.2-fold (0.07 log units) below the measured number; the range from low to high includes it.
By their numbers in this assay, from the lowest: compounds 3, 2 and 4 (each within the scatter of the next); then compound 1.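

In this assay, methyl in place of hydrogen on the double-bonded ring carbon gives a 1.3-fold higher number from compound 3 to compound 4 (0.12 log units; within the scatter) and so leaves the number within the scatter. For the compounds shown here, this is the first reading at this place, since compounds 1, 2 and 3 all carry hydrogen there, and it shows that a single methyl on this ring carbon, next to the ring atom that bears a hydroxy group, brings no shift that this assay can distinguish. Nothing measured here gives a reason for this result.

Going by these compounds alone, what remains open is whether anything larger or of another kind at this ring carbon would behave the same way, such as an ethyl group, a hydroxymethyl group, an amine or a carboxylic acid, since one methyl shows only that this one small group leaves the number within the scatter. Also open, going by these compounds, is whether the same methyl would give a similar result with the side chain of compound 2 or of compound 1, since it has been seen here only with the side chain of compound 3.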